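The source may report more compounds than this note shows. Statements on the series, on what has been measured and on what is new or still open speak of the compounds shown alone.

Measured compounds in a physicochemical assay, with a stated time of 60 min; on this read-out higher numbers stand for weaker inhibition and lower numbers for stronger inhibition:
compound 1, `CCOC(=O)[C@@H]1C(=O)N(Cc2ccccc2)C[C@@H](ON2C(C)(C)CCCC2(C)C)[C@H]1c1ccc(F)cc1`: 15900 nM
compound 2, `CCOC(=O)[C@@H]1C(=O)N(Cc2ccccc2)C[C@@H](O)[C@H]1c1ccc(F)cc1`: > 100000 nM

Compound 2 sits at the limit of this assay, and its value > 100000 nM is a limit of the read-out, not a number. For the measured compounds named here, the only measured step, an at least 6.2-fold higher number from compound 1 to compound 2 (0.79 log units; beyond the scatter), concerns the substituent on the oxygen of the saturated carbon; the size of that step is itself bounded by the limit of > 100000 nM in this assay, at which 1 of the 2 values shown sits.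

Compound 3, `CCOC(=O)[C@@H]1C(=O)N(Cc2ccccc2)C[C@@H](O)[C@H]1c1ccc(C)cc1`, differs from compound 2 by methyl in place of fluoro on an aromatic carbon. Going by the values given here, no measured step touches the aromatic substituent, so the available data give no direction for this change, and the starting point is already a limit. The step that the limit leaves unreadable from compound 2 to compound 3 is therefore expected to stay within the scatter. For compound 3 the estimate in this assay is 120000 nM, within 40000 nM to 400000 nM, with a limit rather than a number the most likely outcome.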

Compound 3, half-maximal inhibitory concentration: > 100000 nM
Compound 3: a limit, no number (the forecaster's own chance of this, stated with the estimate: 75%); the middle value does not contradict the limit.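

In this assay compound 3 gives > 100000 nM, a limit and not a number, as does compound 2, so no step can be read between compound 2 and compound 3: the limit of > 100000 nM in this assay, at which 2 of the 3 values shown sit.

The compounds shown leave open whether 4-fluorophenyl and 4-methylphenyl differ at all in this assay.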